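The compounds below may be only part of what the source reports. "The series", "measured", "known", "first", "only" and "open" are said of these compounds alone.

Among the compounds with values here, of the two numbers so far in an assay on HEK293 cells for inhibition of Steryl-sulfatase (Homo sapiens), tested at 0.1 uM (on this read-out higher numbers stand for a stronger effect at the one concentration tested and lower numbers for a weaker effect), compound 1 `CN(C)CCN(CCN(C)C)c1ccc(C(=O)N2CCc3ccc(OS(N)(=O)=O)cc3C2)cc1` gives 3.8%, and compound 2 `CN(CCN1CCCCC1)c1ccc(C(=O)N2CCc3ccc(OS(N)(=O)=O)cc3C2)cc1` gives 0.3%; the one measured step, a number 3.5 percentage points lower from compound 1 to compound 2 (within the scatter), rebuilds the amine on the aromatic carbon and stays flat. Compound 3 `CN(C)CCN(Cc1ccccc1)c1ccc(C(=O)N2CCc3ccc(OS(N)(=O)=O)cc3C2)cc1` differs from compound 1 by phenyl in place of (dimethylamino)methyl on a saturated chain carbon bound to a nitrogen on an aromatic ring. Within the data shown here, no measured step bears on a phenyl at this place; since the sole comparable change left this assay flat, the step is expected to be small, a number 0.2 percentage points higher from compound 1 to compound 3 (within the scatter). Compound 3 is therefore estimated at 4%, with a range from -6% to 16%.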

Compound 3, a percentage reported as inhibition, at one concentration (the size of the read-out at that concentration, not a potency): 13.9%
Compound 3: middle estimate off by 9.9 percentage points, on the low side; the measured number falls inside the stated range.
By their numbers in this assay, from the lowest: compounds 2 and 1 (each within the scatter of the next); then compound 3.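

In this assay, within the data shown here, this place proves responsive: phenyl in place of (dimethylamino)methyl on a saturated chain carbon bound to a nitrogen on an aromatic ring gives a number 10.1 percentage points higher from compound 1 to compound 3 (beyond the scatter) and is the first step beyond the scatter. The change removes a ringless group carrying a nitrogen and adds an aromatic ring of carbon only, so these two parts of the change cannot be separated here. No available measurement accounts for the step.

Going by these compounds, whether the step follows the aromatic ring or the loss of the amine stays open. Cyclohexyl or pyridyl at this place would help separate the two.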